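Working notes: fluoro-to-chloro swap across two cores

The compounds below may be only part of what the source reports. "The series", "measured", "known", "first", "only" and "open" are said of these compounds alone.

Measured compounds and values in a functional assay on SW 1116 cells (Homo sapiens) for antiproliferative activity, read by MTT assay, with a stated time of 48 h; on this read-out higher numbers stand for weaker inhibition and lower numbers for stronger inhibition:
- compound 1, `Fc1ccc(CSc2nnc(-c3cnccn3)s2)cc1`, gives 17100 nM
- compound 2, `Clc1ccc(CSc2nnc(-c3cnccn3)s2)cc1`, gives 4770 nM
- compound 3, `Fc1ccc(CSc2nnc(-c3cnccn3)n2-c2ccccc2)cc1`, gives 4120 nM

Compound 1 and compound 2 share a core and differ only by chloro in place of fluoro on an aromatic carbon. That change gave a 3.6-fold lower number from compound 1 to compound 2 (0.55 log units; beyond the scatter). Compound 3 carries a different core; the difference between the two cores is not broken down here. In this assay compound 3 gives a number close to that of compound 2, the two lying within the usual scatter of each other, and well below that of compound 1.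

Compound 4, `Clc1ccc(CSc2nnc(-c3cnccn3)n2-c2ccccc2)cc1`, is not yet measured. It differs from compound 3 by chloro in place of fluoro on an aromatic carbon, the same change that separates compound 1 from compound 2. Going by the values given here, the expected step from compound 3 to compound 4 in this assay is a 2.7-fold lower number from compound 3 to compound 4 (0.44 log units; beyond the scatter), resting on the single earlier case a 3.6-fold lower number from compound 1 to compound 2 (0.55 log units; beyond the scatter), with allowance that the change sits on a different core and only one example is known. Compound 4 is therefore estimated at 1500 nM, with a range from 600 nM to 4000 nM.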

Compound 4, half-maximal inhibitory concentration: 12500 nM
Beside the measured number, compound 4's estimate is 8.3-fold (0.92 log units) below it; measured number above the stated range.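

On the core of compound 3, chloro in place of fluoro gives a 3.0-fold higher number from compound 3 to compound 4 (0.48 log units; beyond the scatter) in this assay, so the step runs opposite to the one seen on the core of compound 1. The result shows that, in this series, neither the direction nor the size of this change can be carried from one of these cores to the other, but with a single pair on each core it does not show which part of the core difference goes with the split, and no cause can be assigned. The two steps stand apart by more than repeat measurements would explain: the same change on two cores in this assay, a 3.6-fold lower number (0.55 log units; beyond the scatter) from compound 1 to compound 2 and a 3.0-fold higher number (0.48 log units; beyond the scatter) from compound 3 to compound 4, 11-fold (1.04 log units) apart, beyond the scatter of two such steps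

From the compounds shown here alone, it remains open how bromo, methyl or an amine at the same place would behave on each core, and therefore whether the opposite trends extend beyond fluoro and chloro. Also open, going by these compounds, is whether a longer chain in place of the benzyl link would keep the split between the two cores or remove it.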